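Changing the ether group on compound 3

The source may hold more compounds than are shown below. What is called first, only, known or untested is meant among the compounds shown, and "the series" means these compounds.

In a functional assay on MT2 cells (Homo sapiens) for cytotoxicity, read by MTT assay (a higher number here means that more compound is tolerated, a lower number that less compound is tolerated), compound 1 (`COc1ccc(Nc2nccs2)cc1OCC=C(C)C`) gives 42000 nM, compound 2 (`CCCc1ccc(Nc2nccs2)cc1OCC=C(C)C`) gives 23000 nM and compound 3 (`CC(C)=CCOc1cc(Nc2nccs2)ccc1C#N`) gives 750 nM, the lowest of the three numbers. Compound 4 (`N#Cc1ccc(Nc2nccs2)cc1OCc1ccco1`) has furan-2-yl in place of 2-methylprop-1-en-1-yl on a saturated chain carbon bound to an oxygen on an aromatic ring. For the measured compounds named here, no measured step covers this change, since all three leave the 3-methylbut-2-en-1-yl chain untouched. Replacing a group on an aromatic carbon gave a 56-fold lower number from compound 1 to compound 3 (1.75 log units; beyond the scatter) and a 31-fold lower number from compound 2 to compound 3 (1.49 log units; beyond the scatter), both large, and a 1.8-fold lower number from compound 1 to compound 2 (0.26 log units; within the scatter), within the scatter. Compound 4 keeps the cyano group of compound 3, so no step beyond the scatter is expected in this assay. The estimated step is a 1.6-fold higher number from compound 3 to compound 4 (0.20 log units; within the scatter). The expected value for compound 4 is 1200 nM, with an estimated range of 300 nM to 5000 nM.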

Compound 4, half-maximal cytotoxic concentration: 18000 nM
For compound 4 the middle estimate is 15-fold (1.18 log units) below the measured one, outside the stated range (above it).
By their numbers in this assay, from the lowest: compound 3; then compounds 4, 2 and 1 (each within the scatter of the next, the first and the last beyond it).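

In this assay, for the compounds shown here, furan-2-yl in place of 2-methylprop-1-en-1-yl gives a 24-fold higher number from compound 3 to compound 4 (1.38 log units; beyond the scatter), so the ether chain, untouched in the earlier compounds, also moves this number. With the cyano group kept, the low number of compound 3 does not carry over to compound 4. Nothing on record explains this step.

Going by these compounds, whether the step follows from the furan ring or from losing the 3-methylbut-2-en-1-yl chain stays open; a benzyl or a saturated pentyl ether would help separate the two. Also open, on these data alone, is whether the same change gives a similar step with methoxy or propyl in place of cyano.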